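A few compounds are considered here, and "the series" means these few. Any claim that something is new, unique, unknown or untested is made for them only; others in the source may bear on it.

For the measured compounds named here, compound 2 `COC(CCn1cnc2c(NCc3ccc(C(=O)Nc4ccccc4N)cc3)nc(Cl)nc21)OC` is one of two compounds measured in a functional assay on NCI-H460 cells (Homo sapiens) for antiproliferative activity, read by CCK-8 assay, with a stated time of 72 h, tested at 8 uM (a higher number here means a stronger effect of the compound at the concentration tested, a lower number a weaker effect), where compound 2 gives 51.2%. The other is compound 1 `CC(C)n1cnc2c(Nc3cccc(Cl)c3)nc(NCOCc3ccc(C(=O)Nc4ccccc4N)cc3)nc21`, which in this assay gives 43.2%. Although the number of compound 2 is the higher of the two shown, its gap from compound 1 lies within the usual scatter of repeated measurements, so the two cannot be told apart on these data. Going by the values given here, the two compounds differ at more than one place, and no single-point step between measured compounds is available.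

The step to compound 3 `Nc1ccccc1NC(=O)c1ccc(CNc2nc(Cl)nc3c2ncn3C2CCCC2)cc1` is a single change on the shared core of compound 2: cyclopentyl in place of 3,3-dimethoxypropyl on an aromatic nitrogen. Nothing measured here shows what such a change does to the inhibition in this assay, so the expectation rests only on the two numbers shown, which both sit near the middle of the percentage scale.

Compound 3 is therefore expected to show 48% in this assay, with a range from 28% to 68%. The expected step from compound 2 is a number 3.2 percentage points lower from compound 2 to compound 3 (within the scatter), which is not anticipated to exceed the scatter in either direction.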

Compound 3, a percentage reported as inhibition, at one concentration (the size of the read-out at that concentration, not a potency): 57.4%
Estimate against measurement, compound 3: 9.4 percentage points below, within the range that was stated.
By their numbers in this assay, from the lowest: compounds 1, 2 and 3 (each within the scatter of the next, the first and the last beyond it).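

Exchanging 3,3-dimethoxypropyl for cyclopentyl on an aromatic nitrogen of the five-membered aromatic ring gives, in this assay, a number 6.2 percentage points higher from compound 2 to compound 3 (within the scatter) and is the only single-point reading shown at this position, so compound 2 and compound 3 cannot be told apart on these data. This nitrogen therefore carries either an open chain with 2 hydrogen-bond acceptors or a five-membered ring of carbon only with none, and the inhibition at the single concentration tested does not separate the two beyond the scatter. Nothing available explains this outcome, and no cause can be assigned to it.

On these data alone, whether a methyl group, a 3-aminopropyl chain, a cyclohexyl ring or a longer chain ending in a carboxylic acid on this nitrogen would move the inhibition beyond the scatter remains open. Also open, as far as these compounds go, is whether compound 2 and compound 3 would separate over a range of concentrations, and compound 1 offers no reading on this nitrogen alone, since it differs from both at more than one place.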